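The compounds below may be only part of what the source reports. "The series", "measured", "known", "first", "only" and "open" are said of these compounds alone.

Measured compounds:
compound 1, `CCOc1nc2cccc(C(=O)NCCCN(C)C)c2n1Cc1ccc(-c2ccccc2-c2nnn[nH]2)cc1`, in an assay on isolated protein for inhibition of NEDD8-activating enzyme E1 regulatory subunit (Homo sapiens), read by Western blot, with stated times of 10 min and 30 min, tested at 25 uM (a higher number here means more inhibition at the concentration tested (going by the name of the read-out), a lower number less inhibition), gives 29.5%
compound 2, `CCOc1nc2cccc(C(=O)N[C@H]3CC[C@H](C(=O)OC)CC3)c2n1Cc1ccc(-c2ccccc2-c2nnn[nH]2)cc1`, in this assay gives 28.6%
compound 3, `CCOc1nc2cccc(C(=O)NCc3ccc(F)cc3)c2n1Cc1ccc(-c2ccccc2-c2nnn[nH]2)cc1`, in this assay gives 38.1%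

Compound 3 shows the highest of the three numbers, yet the steps of a number 8.6 percentage points higher from compound 1 to compound 3 (within the scatter) and a number 9.5 percentage points higher from compound 2 to compound 3 (within the scatter) are both within the scatter, as is a number 0.9 percentage points lower from compound 1 to compound 2 (within the scatter), so the three compounds cannot be separated in this assay on the evidence so far.

Compound 4, `CCOc1nc2cccc(C(=O)NOCc3ccccc3)c2n1Cc1ccc(-c2ccccc2-c2nnn[nH]2)cc1`, is the next compound. It differs from compound 3 by benzyloxy in place of 4-fluorobenzyl on an amide-type nitrogen. The change again touches the group carried on the amide-type nitrogen, the same place that was varied in every step above. Those steps swapped groups of quite different kind, and none of them moved the number beyond the scatter. On that basis the step from compound 3 to compound 4 is expected to be no larger than the scatter, with no clear direction, so the estimated step is a number 4.1 percentage points lower from compound 3 to compound 4 (within the scatter). For compound 4 the expected value in this assay is 34%, with a range from 20% to 48%.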

Compound 4, a percentage reported as inhibition, at one concentration (the size of the read-out at that concentration, not a potency): 39.8%
Compound 4: the middle estimate sits 5.8 percentage points below what was measured; the range from low to high includes it.
By their numbers in this assay, from the lowest: compounds 2, 1, 3 and 4 (each within the scatter of the next, the first and the last beyond it).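

In this assay, among these compounds, the group on the amide-type nitrogen now yields separations beyond the scatter, both modest: a number 11.2 percentage points higher from compound 2 to compound 4 (beyond the scatter) and a number 10.3 percentage points higher from compound 1 to compound 4 (beyond the scatter) are the first steps at this position to clear it. Compound 3 does not share this separation from compound 1 and compound 2, so benzyloxy is set apart from 3-(dimethylamino)propyl and 4-(methoxycarbonyl)cyclohexyl while 4-fluorobenzyl is not, even though a number 1.7 percentage points higher from compound 3 to compound 4 (within the scatter) shows that exchanging 4-fluorobenzyl for benzyloxy, two groups of equal heavy-atom count with one carbon-only aromatic ring each, cannot be read as a real difference. No measurement shown bears on why benzyloxy stands apart from those two groups.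

Still open, on these data alone, is whether the oxygen of benzyloxy matters at all, a question that a plain benzyl group on the same nitrogen or a longer chain between the oxygen and the phenyl ring would address. Also open, as far as these compounds go, is how a carboxylic acid in place of the methyl ester of compound 2 would read, and since every number comes from one tested concentration, none of them gives a potency.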